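This account rests on a few compounds, and the source may have more. Where it says the series, first, only, none or still open, it means among the compounds named here.

Working notes on the series. In a functional assay on A-431 cells (Homo sapiens) for inhibition, read by MTT assay, with a stated time of 72 h (a lower number here means a stronger inhibitor, a higher number a weaker inhibitor), compound 1 `Fc1ccc(-c2nnc(SCCCN3CCN(c4nc5ccccc5o4)CC3)o2)cc1` gives 136000 nM, compound 2 `Clc1ccc(-c2nnc(SCCCN3CCN(c4nc5ccccc5s4)CC3)o2)cc1` gives 69200 nM, and compound 3 `Fc1ccc(-c2nnc(SCCCN3CCN(c4nc5ccccc5s4)CC3)o2)cc1` gives 67000 nM. Compound 3 cannot be told apart from compound 2 on these numbers, and it stands clear of compound 1 only by a modest margin, just beyond the scatter.

The next structure is compound 4 `c1ccc(-c2nnc(SCCCN3CCN(c4nc5ccccc5s4)CC3)o2)cc1`, which has hydrogen in place of fluoro on an aromatic carbon, para to a large group, so that 4-fluorophenyl becomes phenyl (hydrogen in place of fluoro on an aromatic carbon).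

Two measured steps are available. The one that bears directly on this place is a 1.0-fold lower number from compound 2 to compound 3 (0.01 log units; within the scatter), with fluoro in place of chloro on an aromatic carbon, and it lies within the scatter. The other, a 2.0-fold lower number from compound 1 to compound 3 (0.31 log units; beyond the scatter), is a change elsewhere in the structure and gives no direct guide here. Among the measured compounds shown here, no measured compound has hydrogen at this place, so the data do not test this exchange itself. The fluoro and chloro pair gives no reason to expect a real shift in this assay. The estimated step is a 1.0-fold higher number from compound 3 to compound 4 (0.02 log units; within the scatter), which is expected to stay within the scatter, with no direction favoured. For compound 4 the expected value is 70000 nM, with an estimated range of 35000 nM to 140000 nM.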

Compound 4, half-maximal inhibitory concentration: 93400 nM
The estimate for compound 4 lay 1.3-fold (0.13 log units) below the measured number, and the stated range covers the measured number.
By their numbers in this assay, from the lowest: compounds 3, 2, 4 and 1 (each within the scatter of the next, the first and the last beyond it).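

With the halogen gone from this place, hydrogen in place of fluoro gives a 1.4-fold higher number from compound 3 to compound 4 (0.14 log units; within the scatter) in this assay and hydrogen in place of chloro gives a 1.3-fold higher number from compound 2 to compound 4 (0.13 log units; within the scatter) in the same assay, so neither step can be told from the scatter. The earlier compounds shown here compared only two halogens at this place, whereas compounds 2, 3 and 4 now show that, with 1,3-benzothiazol-2-yl held constant, chloro, fluoro and hydrogen on this aromatic carbon cannot be separated on these numbers. A halogen on the phenyl ring is therefore not required for a reading in this range in this series, although this rests on three compounds and one assay. No evidence on the cause of these readings is available here.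

On these data alone, it remains open whether a different kind of group on the same aromatic carbon, such as methoxy, an amine or a carboxylic acid, would give a step beyond the scatter. Also open, as far as these compounds go, is whether phenyl paired with 1,3-benzoxazol-2-yl would track the 4-fluorophenyl compound with that same group.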